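The source may hold more compounds than are shown below. What is called first, only, known or untested is meant among the compounds shown, and "the series" means these compounds.

Measured so far:
compound 1, `CCCCCCCC/C=C\CCCCCCCC(=O)Nc1nnc(S[C@@H]2O[C@H](COC(C)=O)[C@H](OC(C)=O)[C@H](OC(C)=O)[C@H]2OC(C)=O)s1` — 42000 nM
compound 2, `CCCCCCCCCCCC(=O)Nc1nnc(S[C@@H]2O[C@H](CO)[C@H](O)[C@H](O)[C@H]2O)s1` — "not active" (no number reported)
compound 3, `CCCCCCCCCCCCCC(=O)Nc1nnc(S[C@@H]2O[C@H](CO)[C@H](O)[C@H](O)[C@H]2O)s1` — "not active" (no number reported)

Among the compounds with values here, in a functional assay on DU-145 cells (Homo sapiens) for cytotoxicity, read by MTT assay, with a stated time of 24 h (on this read-out higher numbers stand for weaker inhibition and lower numbers for stronger inhibition), compound 1 gives 42000 nM, the only number reported in this set; compound 2 gives "not active" (no number reported) and compound 3 gives "not active" (no number reported), each with no number given. Compound 4, `CCCCCCCCCCCC(=O)Nc1nnc(S[C@@H]2O[C@H](COC(C)=O)[C@H](OC(C)=O)[C@H](OC(C)=O)[C@H]2OC(C)=O)s1`, differs from compound 1 as follows: butyl in place of dec-1-en-1-yl on a saturated chain carbon, seven bonds along the chain from a carbonyl carbon. Within the data shown here, since no step between two measured compounds is available, the size of this step is uncertain. Compound 4 is expected to show weaker inhibition in this assay than compound 1, by a step of a 1.7-fold higher number from compound 1 to compound 4 (0.22 log units; within the scatter) that lies somewhat beyond the scatter. The estimated value of compound 4 in this assay is 70000 nM, with a range of 28000 nM to 180000 nM.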

Compound 4, half-maximal inhibitory concentration: 16900 nM
Compound 4: middle estimate off by 4.1-fold (0.62 log units), on the high side; measured number outside the range, below it.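

In this assay, within the data shown here, the change of dec-1-en-1-yl to butyl gives a 2.5-fold lower number from compound 1 to compound 4 (0.40 log units; beyond the scatter) and provides the first readable step in this set, showing that this chain position tolerates the change with stronger inhibition. The change removes the double bond and shortens the chain together, so the step cannot be assigned to either alone. Nothing measured here accounts for the step. The compounds shown leave open how a saturated chain of the original length would compare, and whether a chain ending in an amine or a carboxylic acid would keep this inhibition.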